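Swapping methoxy for methyl on the amide aryl group

A few compounds are considered here, and "the series" means these few. Any claim that something is new, unique, unknown or untested is made for them only; others in the source may bear on it.

Three compounds share a common core and differ only in the aryl group attached to the amide carbonyl. Compound 1 `O=C(Nc1cccc(-c2oc3cc(-c4ccc(F)cc4)ccc3c(=O)c2O)c1)c1ccccc1F` gives 17400 nM in a functional assay on GTL 16 cells for antiproliferative activity against GTL 16 cell line (Homo sapiens), read by CCK-8 assay, with a stated time of 72 h; on this read-out lower numbers stand for stronger inhibition and higher numbers for weaker inhibition. Compound 2 `O=C(Nc1cccc(-c2oc3cc(-c4ccc(F)cc4)ccc3c(=O)c2O)c1)c1ccc(F)cc1F` gives 9640 nM, and compound 3 `COc1cc(OC)cc(C(=O)Nc2cccc(-c3oc4cc(-c5ccc(F)cc5)ccc4c(=O)c3O)c2)c1` gives 19600 nM. Compound 3 thus gives the highest of the three numbers, though one of the two gaps is a 1.1-fold higher number from compound 1 to compound 3 (0.05 log units; within the scatter), while the other is a 2.0-fold higher number from compound 2 to compound 3 (0.31 log units; beyond the scatter). Compound 4 `Cc1cc(C)cc(C(=O)Nc2cccc(-c3oc4cc(-c5ccc(F)cc5)ccc4c(=O)c3O)c2)c1` is not yet measured; it differs from compound 3 in one place: 3,5-dimethylphenyl in place of 3,5-dimethoxyphenyl on a carbonyl carbon. The two measured steps that exchanged the aryl group on the carbonyl carbon, a 1.1-fold higher number from compound 1 to compound 3 (0.05 log units; within the scatter) and a 2.0-fold higher number from compound 2 to compound 3 (0.31 log units; beyond the scatter), were both small, and the one that altered a single ring substituent, a 1.8-fold lower number from compound 1 to compound 2 (0.26 log units; within the scatter), was also small. Exchanges at this position have so far moved the numbers little, so the expected step from compound 3 to compound 4 is a 1.3-fold lower number from compound 3 to compound 4 (0.12 log units; within the scatter), with no clear direction beyond the scatter. Compound 4 is therefore estimated at 15000 nM, within a range of 6000 nM to 40000 nM.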

Compound 4, half-maximal inhibitory concentration: 13500 nM
Compound 4: the middle estimate sits 1.1-fold (0.05 log units) above what was measured; measured number inside the range.
By their numbers in this assay, from the lowest: compounds 2, 4, 1 and 3 (each within the scatter of the next, the first and the last beyond it).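

Taking out the two oxygen atoms leaves an aryl group with no hydrogen-bond acceptors, yet this assay shows only a step within the scatter (a 1.5-fold lower number from compound 3 to compound 4 (0.16 log units; within the scatter)). Compound 4, whose ring carries only carbon substituents, also stays within the scatter of both fluorinated compounds (a 1.4-fold higher number from compound 2 to compound 4 (0.15 log units; within the scatter); a 1.3-fold lower number from compound 1 to compound 4 (0.11 log units; within the scatter)), so at this position the oxygen atoms of the methoxy groups are not needed to keep the activity seen in compound 3. No available evidence explains why these exchanges on the carbonyl carbon make so little difference.

From the compounds shown here alone, all four compounds carry a substituted phenyl group here, so it remains open whether an aryl group bearing an amine or a carboxylic acid would behave the same way. A saturated ring such as cyclohexyl on the carbonyl carbon is also untested among these compounds.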